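This account rests on a few compounds, and the source may have more. Where it says the series, first, only, none or still open, it means among the compounds named here.

Three compounds have been measured in a physicochemical assay for lipophilicity, read by HPLC, with a stated time of 90 min, tested at 100 uM (on this read-out lower numbers stand for lower lipophilicity and higher numbers for higher lipophilicity), so far

compound 1 `O=C(Nc1ccc(OC(F)(F)F)cc1)NC1CCN(C(=O)C2CCOCC2)CC1` gives 3.26
compound 2 `CC[C@H](C)C(=O)N1CCC(CC(=O)Nc2ccc(OC(F)(F)F)c(F)c2)CC1` gives 7.68
compound 3 `O=C(Nc1ccc(OC(F)(F)F)c(F)c1)NC1CCN(C(=O)C2CCOCC2)CC1` gives 3.73

Of these three, compound 1 at 3.26 has the lowest number, and compound 3 and compound 2 both stand higher. Going by the values given here, compound 4 `O=C(Nc1ccc(OC(F)(F)F)cc1)NC1CCN(C(=O)C2=COCC2)CC1` has no measurement yet. It differs from compound 1 in one place, on a carbonyl carbon, with a group of 5 heavy atoms (4 carbon, 1 oxygen; one five-membered non-aromatic ring with 1 hetero atom) in place of a group of 6 heavy atoms (5 carbon, 1 oxygen; one six-membered non-aromatic ring with 1 hetero atom), on a carbonyl carbon as the whole change.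

Among the compounds with values here, only one measured step involves a single place. It is modest, a number 0.47 log units higher from compound 1 to compound 3 (beyond the scatter), and it is a fluoro in place of hydrogen on an aromatic carbon, not a change on the carbonyl carbon. It offers only a rough sense of how far one small replacement can move this assay in this small set. Compound 2 at 7.68 differs from compound 1 in more than one place and gives no clean guide. Within the data shown here, no measured compound changes the group on the carbonyl carbon, and the data do not show a direction for this swap.

No step beyond the scatter is therefore expected, and the estimated step is a number 0.06 log units lower from compound 1 to compound 4 (within the scatter) with a wide margin on either side. For compound 4 the expected value is 3.2, with an estimated range from 2.7 to 3.7.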

Compound 4, partition coefficient: 3.49
Compound 4: middle estimate off by 0.29 log units, on the low side; measured number inside the range.
By their numbers in this assay, from the lowest: compounds 1, 4 and 3 (each within the scatter of the next, the first and the last beyond it); then compound 2.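

In this assay, going by these compounds alone, this is the first measured change on the carbonyl carbon attached to the amide-type nitrogen in a ring: oxan-4-yl gives way to a five-membered non-aromatic ring with 1 hetero atom and 1 double bond outside aromatic rings, and the result is a number 0.23 log units higher from compound 1 to compound 4 (within the scatter). At this place, then, replacing a group of 6 heavy atoms with one of 5 leaves the read-out within the usual variation between repeated measurements, while the fluoro replacement on an aromatic carbon, a number 0.47 log units higher from compound 1 to compound 3 (beyond the scatter), goes beyond it. No independent measurement is available to explain the size of this step.

The ring size and the double bond change together here, so the compounds shown cannot separate the two, and they do not show whether the same swap would give a similar step in the fluoro-bearing compound 3. From the compounds shown here alone, how the read-out would respond at this carbonyl carbon to a group carrying an amine or a carboxylic acid, or to a longer chain, also stays open.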